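Hydrazone aryl swap on the shared core

A few compounds are considered here, and "the series" means these few. Any claim that something is new, unique, unknown or untested is made for them only; others in the source may bear on it.

compound 1 `Cn1c(=O)c(=O)n(C2CCCC2)c2nc(N/N=C/c3ccc(Cl)cc3)ncc21` — 9810 nM
compound 2 `COc1ccc(/C=N/Nc2ncc3c(n2)n(C2CCCC2)c(=O)c(=O)n3C)c(OC)c1` — > 100000 nM

In a functional assay on HCT-116 cells (Homo sapiens) for antiproliferative activity, read by MTT assay (a higher number here means a weaker inhibitor, a lower number a stronger inhibitor), compound 1 gives 9810 nM. Compound 2 reports only a limit of the assay, > 100000 nM. the limit of > 100000 nM in this assay, at which 1 of the 2 values shown sits, applies to compound 2 alone, so compound 2 stands at the weak end of the two values shown, without a number of its own. For the measured compounds named here, the single measured step, an at least 10-fold higher number from compound 1 to compound 2 (1.00 log units; beyond the scatter), runs toward that limit.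

Compound 3 `Cn1c(=O)c(=O)n(C2CCCC2)c2nc(N/N=C/c3ccccc3Cl)ncc21` is not yet measured; it differs from compound 2 by 2-chlorophenyl in place of 2,4-dimethoxyphenyl on a carbon with a double bond to nitrogen. This largely reverses the aryl part of the measured step, with 2-chlorophenyl rather than the 4-chlorophenyl of compound 1, so a full return to the value of compound 1 is not assumed. From the limit of compound 2 the step of an at least 5.5-fold lower number from compound 2 to compound 3 (0.74 log units; beyond the scatter) is expected, toward a lower number. Compound 3 is therefore estimated at 18000 nM, within 5000 nM to 70000 nM.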

Compound 3, half-maximal inhibitory concentration: 14000 nM
Beside the measured number, compound 3's estimate is 1.3-fold (0.11 log units) above it; the measured number falls inside the stated range.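

In this assay, 2-chlorophenyl in place of 2,4-dimethoxyphenyl on the carbon with a double bond to nitrogen gives an at least 7.1-fold lower number from compound 2 to compound 3 (0.85 log units; beyond the scatter), so activity at this place returns with a second chlorophenyl and is not tied to 4-chlorophenyl alone. Compound 2 has only a limit of the assay, so the step from it has a bound and no exact size: the limit of > 100000 nM in this assay, at which 1 of the 3 values shown sits.

The change from 4-chlorophenyl to 2-chlorophenyl gives a 1.4-fold higher number from compound 1 to compound 3 (0.15 log units; within the scatter), which lies within the scatter, so these two groups cannot be told apart in this assay.

Still open, from the compounds shown here alone, is whether a single methoxy group, as in 2-methoxyphenyl or 4-methoxyphenyl, reads like the 2,4-dimethoxyphenyl of compound 2 or like the chlorophenyl groups. Also open, going by these compounds, is how an unsubstituted phenyl or a 4-aminophenyl would read at this place.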